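The source may hold more compounds than are shown below. What is called first, only, known or untested is meant among the compounds shown, and "the series" means these compounds.

Compound 1 `CCN(Cc1cccs1)C(=O)COc1ccc(F)cc1` is the anchor of this small set. Among the compounds with values here, in an assay on HEK293 cells for agonist activity at transient receptor potential cation channel subfamily M member 8 (Homo sapiens), read by fluorescence and calcium flux, with a stated time of 15 min (a higher number here means that more compound is needed for the effect, a lower number that less compound is needed), compound 1 gives 422 nM, and that is the only number the set holds. Within the data shown here, compound 2 `CCN1C(=O)C(Oc2ccc(C)cc2)C1c1cccs1`, built on a different core, in this assay gives "active" (no number reported), so it offers no figure to rank against compound 1 and no step between measured compounds can be drawn.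

The one move to follow leads to compound 3 `CCCc1ccc(OCC(=O)N(CC)Cc2cccs2)cc1`. It differs from compound 1 in a single place: propyl in place of fluoro on an aromatic carbon. Among the measured compounds shown here, no measured pair in the set shows what this exchange does, so the expectation rests on compound 1 alone and on the size of the group that enters.

The step from compound 1 to compound 3 is expected to be modest, toward less compound being needed, of about a 2.1-fold lower number from compound 1 to compound 3 (0.32 log units; beyond the scatter). Compound 3 in this assay is therefore estimated at 200 nM, with a likely range from 60 nM to 700 nM.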

Compound 3, half-maximal effective concentration: 1810 nM
Estimate against measurement, compound 3: 9.1-fold (0.96 log units) below, outside the stated range (above it).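

In this assay, within the data shown here, the exchange of fluoro for propyl on this aromatic carbon, para to a large group, gives a 4.3-fold higher number from compound 1 to compound 3 (0.63 log units; beyond the scatter) as the first measured step in the set. It shows that this position is sensitive to the group it carries: no ring, hydrogen-bond donor, hydrogen-bond acceptor or net charge enters or leaves, yet the larger group goes with more compound being needed for the effect. Nothing at hand accounts for this direction.

The compounds shown leave open whether an ethyl group, a longer chain, a methoxy group or an amine at this place would move the number the same way. They also leave open whether the step follows from the propyl entering or the fluoro leaving, as this single exchange does both at once.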